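Pentyl on Selenium and Growth Inhibition in Bronchial Cells

The source may hold more compounds than are shown below. What is called first, only, known or untested is meant among the compounds shown, and "the series" means these compounds.

Compound 1, `CCCCC[Se]c1nc(NCc2ccc(SC)cc2)c2ccccc2n1`, gives 88200 nM in an ADME assay on BEAS-2B cells (Homo sapiens) for cytotoxicity, read by MTT assay, with a stated time of 72 h; a higher number here means a weaker inhibitor of growth, a lower number a stronger inhibitor of growth.
Compound 2, `CSc1ccc(CNc2nc([SeH])nc3ccccc23)cc1`, gives 58200 nM in this assay.
Compound 3, `Nc1nc([SeH])nc2ccccc12`, gives only a limit of the assay, > 100000 nM, in this assay.

The change from compound 2 to compound 1 is pentyl in place of hydrogen on a selenium, and it produced a 1.5-fold higher number from compound 2 to compound 1 (0.18 log units; within the scatter). Compound 4, `CCCCC[Se]c1nc(N)c2ccccc2n1`, is not yet measured. It arises from compound 3 by pentyl in place of hydrogen on a selenium, the same change. The difference between the cores of compound 3 and compound 2 is not broken down here. Compound 3 sits at the limit of > 100000 nM in this assay, at which 1 of the 3 values shown sits, so only a limit is known for it. Because the same change gave a 1.5-fold higher number from compound 2 to compound 1 (0.18 log units; within the scatter), compound 4 is expected to give 130000 nM in this assay. The expected range for compound 4 runs from 60000 nM to 300000 nM. This expectation means a step that the limit leaves unreadable from compound 3 to compound 4, and another limit is the likely report.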

Compound 4, concentration for total growth inhibition: > 100000 nM
Compound 4 was reported as a limit; the forecaster's own chance of this, stated with the estimate: 70%; the middle value lies beyond the limit too.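

Within the data shown here, compound 3 and compound 4 both sit at a limit of this assay, so no step between them can be read: the limit of > 100000 nM in this assay, at which 2 of the 4 values shown sit.
As far as these compounds go, whether pentyl in place of hydrogen on a selenium changes growth inhibition on the core of compound 3 remains open.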